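Fluoro on the Aryl Ring in Two Related Series

A few compounds are considered here, and "the series" means these few. Any claim that something is new, unique, unknown or untested is made for them only; others in the source may bear on it.

Measured so far: compound 1 `COc1cc(N(Cc2ccc(F)cc2)S(=O)(=O)c2ccc(C)cc2)cc(OC)c1OC` gives 19200 nM in a functional assay on MCF7 cells (Homo sapiens) for inhibition, read by MTT assay, with a stated time of 48 h; on this read-out lower numbers stand for stronger inhibition and higher numbers for weaker inhibition. Compound 2 `COc1cc(N(Cc2ccccc2)S(=O)(=O)c2ccc(C)cc2)cc(OC)c1OC` gives 10200 nM. Compound 3 `COc1cc(N(Cc2nc3ccccc3[nH]2)C(=O)c2ccccc2)cc(OC)c1OC` reaches only a limit of the assay, > 50000 nM.

The change fluoro in place of hydrogen on an aromatic carbon gives a 1.9-fold higher number from compound 2 to compound 1 (0.27 log units; within the scatter), so in the measured pair the added fluorine did not shift the read-out beyond scatter. How the core of compound 3 differs from the core of compound 2 is not broken down here. Compound 4 `COc1cc(N(Cc2nc3ccccc3[nH]2)C(=O)c2ccc(F)cc2)cc(OC)c1OC` carries the same change, (fluoro in place of hydrogen on an aromatic carbon), made on compound 3. Because compound 3 sits at the limit of > 50000 nM in this assay, at which 1 of the 3 values shown sits, and because the measured step of a 1.9-fold higher number from compound 2 to compound 1 (0.27 log units; within the scatter) stayed within scatter, compound 4 is expected to remain near or beyond that limit, with an estimated step that the limit leaves unreadable from compound 3 to compound 4. The estimate for compound 4 is 60000 nM, between 30000 nM and 150000 nM.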

Compound 4, half-maximal inhibitory concentration: 45200 nM
Compound 4: the middle estimate sits 1.3-fold (0.12 log units) above what was measured, and the stated range covers the measured number.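

Compound 3 gives > 50000 nM in this assay, which is a limit of the assay and not a number. Carried to this second core, as phenyl to 4-fluorophenyl within the benzoyl group, the change gives an at least 1.1-fold lower number from compound 3 to compound 4 (0.04 log units; that floor lies within the scatter), so no shift beyond the scatter can be claimed here. The data do not show whether the change acts alike on the two cores: the same change on two cores in this assay, a 1.9-fold higher number (0.27 log units; within the scatter) from compound 2 to compound 1 and an at least 1.1-fold lower number (0.04 log units; that floor lies within the scatter) from compound 3 to compound 4; the limit leaves it open whether they differ

The compounds shown leave open how an amine or a carboxylic acid would read in place of the fluoro. With one pair on each core, they also leave open whether the fluoro change would read the same on further cores.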